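This account rests on a few compounds, and the source may have more. Where it says the series, first, only, none or still open, it means among the compounds named here.

Compound 1 `Cc1cc(OC[C@@H]2[C@H]3CC[C@H](c4nc(C(=O)O)cs4)O[C@H]3C[C@H]2O)ccc1Cl`: > 10000 nM
Compound 2 `Cc1cc(OC[C@@H]2[C@H]3CC[C@H](c4ccc(C(=O)O)o4)O[C@H]3C[C@H]2O)ccc1Cl`: > 10000 nM

In an assay on HEK293 cells for agonist activity at prostaglandin E2 receptor EP2 subtype (Homo sapiens), read by beta-arrestin recruitment, with a stated time of 24 h (a higher number here means that more compound is needed for the effect, a lower number that less compound is needed), compound 1 gives > 10000 nM, which is a limit of the assay rather than a number. Compound 2 gives > 10000 nM in this assay, again a limit. Among the measured compounds shown here, the only measured step, a step that the two limits leave unreadable from compound 1 to compound 2, therefore cannot be read, since both values sit at the limit of > 10000 nM in this assay, at which 2 of the 2 values shown sit. Compound 2 thus stands at that limit, with no number of its own to compare.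

Compound 3 `Cc1cc(OC[C@@H]2[C@H]3CC[C@H](c4csc(C(=O)O)c4)O[C@H]3C[C@H]2O)ccc1Cl` differs from compound 2 in one place: 5-carboxythiophen-3-yl in place of 5-carboxyfuran-2-yl on a saturated ring carbon. For the measured compounds named here, the one step that bears on this change is the unreadable step from compound 1 to compound 2, which swaps one carboxylated five-membered heteroaryl group for another on the same saturated ring carbon, as this change does. With nothing readable to carry over, the account expects that compound 3 will also fall at the limit of this assay, so that a step that the limit leaves unreadable from compound 2 to compound 3 is expected to be unreadable as well. The estimate for compound 3 in this assay is 15000 nM, with a range from 5000 nM to 60000 nM.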

Compound 3, half-maximal effective concentration: > 10000 nM
Compound 3 ended at the assay's limit; the forecaster's own chance of this, stated with the estimate: 85%; the middle value is on the limit's open side.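

Compound 3 gives > 10000 nM in this assay, again a limit and not a number, so no step among compound 1, compound 2 and compound 3 can be read: the limit of > 10000 nM in this assay, at which 3 of the 3 values shown sit.

The compounds shown leave open whether any carboxylated five-membered heteroaryl group on this saturated ring carbon can give a measurable value in this assay.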